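Swapping Methoxy for Ethoxy on Compound 3

This account rests on a few compounds, and the source may have more. Where it says the series, first, only, none or still open, it means among the compounds named here.

Of the compounds shown here, three built on one shared core have been tested in an ADME assay on HEK293 cells (Homo sapiens) for cytotoxicity, read by MTT assay, with a stated time of 48 h; a lower number here means a stronger inhibitor, a higher number a weaker inhibitor. There, compound 1 `COc1ccc(/C=C2/S/C(=N/c3ccccc3)N(Cc3ccncc3)C2=O)cc1` gives 47900 nM, compound 2 `CN(C)c1ccc(/C=C2/S/C(=N/c3ccccc3)N(Cc3ccncc3)C2=O)cc1` gives 122000 nM, and compound 3 `COc1cc(/C=C2/S/C(=N/c3ccccc3)N(Cc3ccncc3)C2=O)ccc1O` gives 67400 nM. Compound 3 cannot be told apart from either of the others, as both of its steps stay within the scatter: a 1.4-fold higher number from compound 1 to compound 3 (0.15 log units; within the scatter) and a 1.8-fold lower number from compound 2 to compound 3 (0.26 log units; within the scatter). For the measured compounds named here, only one step among the three goes beyond the scatter, and it is modest: a 2.5-fold higher number from compound 1 to compound 2 (0.41 log units; beyond the scatter), where dimethylamino replaces methoxy.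

Compound 4 `CCOc1cc(/C=C2/S/C(=N/c3ccccc3)N(Cc3ccncc3)C2=O)ccc1O` differs from compound 3 by a single small edit, (methyl in place of hydrogen on a saturated chain carbon bound to an oxygen on an aromatic ring). This places methyl in place of hydrogen on a saturated chain carbon bound to an oxygen on an aromatic ring, so that methoxy becomes ethoxy. Going by the values given here, no measured pair makes this exact change, so the evidence is indirect. Larger swaps on the aromatic ring gave only a 2.5-fold higher number from compound 1 to compound 2 (0.41 log units; beyond the scatter) and a 1.4-fold higher number from compound 1 to compound 3 (0.15 log units; within the scatter), so this smaller edit is expected to stay within the scatter, with no clear direction. The expected change is a 1.0-fold higher number from compound 3 to compound 4 (0.02 log units; within the scatter). For compound 4 the estimated value is 70000 nM, with an expected range of 35000 nM to 140000 nM.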

Compound 4, half-maximal inhibitory concentration: 46500 nM
Compound 4: the middle estimate sits 1.5-fold (0.18 log units) above what was measured; the measured number falls inside the stated range.
By their numbers in this assay, from the lowest: compounds 4, 1, 3 and 2 (each within the scatter of the next, the first and the last beyond it).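

In this assay, for the compounds shown here, compound 3 and compound 4 form the only measured pair that makes this exact change, methoxy to ethoxy, and the added methyl on the saturated chain carbon bound to an oxygen on an aromatic ring gives a 1.4-fold lower number from compound 3 to compound 4 (0.16 log units; within the scatter) and so cannot be told apart from no change. Compound 4 also stays level with the methoxy-only aromatic group, with a 1.0-fold lower number from compound 1 to compound 4 (0.01 log units; within the scatter) within the scatter, but it shows a 2.6-fold lower number from compound 2 to compound 4 (0.42 log units; beyond the scatter) and so stands modestly apart from the dimethylamino compound, a separation that compound 3 did not reach. No measurement shown here explains why these numbers fall as they do.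

The compounds shown stop at ethoxy, so it remains open whether a longer chain such as propoxy or butoxy at this place would also stay within the scatter or would begin to shift the number. As far as these compounds go, it is also open whether an amine or a carboxylic acid on that chain would move the number in this cell assay.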